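Lengthening a Chain: Lipophilicity Across Two Related Cores

The compounds below may be only part of what the source reports. "The series", "measured", "known", "first", "only" and "open" are said of these compounds alone.

Compound 1, `CCCCCN(C)/N=N/c1ccc(C(=O)O)cc1`, gives 1.49 in a physicochemical assay for lipophilicity; on this read-out higher numbers stand for higher lipophilicity and lower numbers for lower lipophilicity.
Compound 2, `CCCCCCCN(C)/N=N/c1ccc(C(=O)O)cc1`, gives 2.58 in this assay.
Compound 3, `CCN(C)/N=N/c1ccc(C(N)=O)cc1`, gives 1.7 in this assay.

Compound 4, `CCCCN(C)/N=N/c1ccc(C(N)=O)cc1`, has not yet been measured. It differs from compound 3 by ethyl in place of hydrogen on a saturated chain carbon, two bonds along the chain from an amine nitrogen. The same kind of change is seen from compound 1 to compound 2, where it reads (ethyl in place of hydrogen on a saturated chain carbon, five bonds along the chain from an amine nitrogen); the entering ethyl sits five bonds along the chain from the amine nitrogen there, but two bonds along in compound 4. That earlier step gave a number 1.09 log units higher from compound 1 to compound 2 (beyond the scatter). How the core of compound 3 differs from that of compound 1 is not broken down here; compound 3 and compound 1 give numbers within the usual scatter of each other. In this assay the step from compound 3 to compound 4 is expected to be about a number 1.00 log units higher from compound 3 to compound 4 (beyond the scatter), resting on the earlier step of a number 1.09 log units higher from compound 1 to compound 2 (beyond the scatter). Compound 4 is therefore estimated at 2.7, most likely between 2.3 and 3.1.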

Compound 4, partition coefficient: 2.46
Beside the measured number, compound 4's estimate is 0.24 log units above it; the measured number falls inside the stated range.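

Ethyl in place of hydrogen gives a number 0.76 log units higher from compound 3 to compound 4 (beyond the scatter) and, on the other core, gives a number 1.09 log units higher from compound 1 to compound 2 (beyond the scatter) so in this assay the change goes the same way on both cores. Among the compounds shown here, these are only two steps, and they differ in the core as well as in the place of the entering ethyl, so they cannot separate those two influences on the size of the step or show that it would carry to any further core. Nothing here bears on why the number rises in either case.

Still open, from the compounds shown here alone, is whether the same change holds on a core carrying a nitrile in place of the amide or the carboxylic acid. Also open, going by these compounds, is what a cyclohexyl group at the end of the chain would give.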